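Swapping a sulfur-linked side chain for a phenylamine

The source may report more compounds than this note shows. Statements on the series, on what has been measured and on what is new or still open speak of the compounds shown alone.

Compound 1, `OCCSCc1ncnc2c1ncn2[C@@H]1O[C@H](CO)[C@@H](O)[C@H]1O`, carries a (2-hydroxyethyl)sulfanyl group on the chain carbon attached to its core. In a functional assay on Huh-7 cells (Homo sapiens) for cytotoxicity, read by MTT assay, with a stated time of 3 days (a higher number here means that more compound is tolerated, a lower number that less compound is tolerated), compound 1 gives > 100000 nM, which is a limit of the assay rather than a number. Two other compounds share parts of this core. Compound 2, `OC[C@H]1O[C@@H](n2cnc3c(CS)ncnc32)C[C@@H]1O`, gives 41000 nM in this assay. Compound 3, `OC[C@H]1O[C@@H](n2cnc3c(CSc4nc5ccccc5s4)ncnc32)[C@H](O)[C@@H]1O`, gives > 100000 nM in this assay, again a limit. Going by the values given here, the one directly comparable step, a step that the two limits leave unreadable from compound 1 to compound 3, cannot be sized, since both ends rest on (the limit of > 100000 nM in this assay, at which 2 of the 3 values shown sit).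

Compound 4, `CN(Cc1ncnc2c1ncn2[C@@H]1O[C@H](CO)[C@@H](O)[C@H]1O)c1ccccc1`, is the next compound in line. The change from compound 1 is methyl(phenyl)amino in place of (2-hydroxyethyl)sulfanyl on a saturated chain carbon bound to an aromatic carbon. Among the compounds with values here, no measured step covers this exact exchange; the only measured step at the same position is the unreadable one from compound 1 to compound 3. With two of three values sitting at the limit and the third, compound 2, not far from it, the expectation is that compound 4 also tolerates high concentrations, with a step of a number no higher from compound 1 to compound 4 (the limit leaves the size open) expected, no larger than the scatter. The estimate for compound 4 is therefore 100000 nM, in the range 40000 nM to 250000 nM.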

Compound 4, half-maximal cytotoxic concentration: 21000 nM
For compound 4 the middle estimate is 4.8-fold (0.68 log units) above the measured one, and the stated range ends above it.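

Going by these compounds alone, at this position the side chain does matter for how much compound the cells tolerate: in this assay the exchange gives an at least 4.7-fold lower number from compound 1 to compound 4 (0.67 log units; beyond the scatter), the first step here whose size can be read at all. Compound 3, whose side chain also holds aromatic rings, gives > 100000 nM, which is a limit of the assay, so among the compounds shown an aromatic ring in the side chain is not enough on its own to bring the number down. The step itself gives only a smallest possible size, and its true size stays open at the upper end: the limit of > 100000 nM in this assay, at which 2 of the 4 values shown sit.

The exchange replaces the sulfur link, removes the hydroxyl end of the chain and adds both the methyl and the phenyl ring in one move, so these compounds cannot show which of those parts accounts for the lower number. A phenylsulfanyl group, which keeps the ring on a sulfur link, or a dimethylamino group, which keeps the nitrogen without the ring, would be the kind of neighbour that could separate those parts on the same chain carbon.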